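From Compound 2 to a Hydroxy-Bearing Compound 3

The source may hold more compounds than are shown below. What is called first, only, known or untested is meant among the compounds shown, and "the series" means these compounds.

In a functional assay on DWD cells (Homo sapiens) for inhibition, read by sulforhodamine B assay (on this read-out higher numbers stand for weaker inhibition of growth and lower numbers for stronger inhibition of growth), compound 1 (`COc1ccc(-c2ccc(-c3ccc(-c4nc5ccccc5[nH]4)cc3)cc2)cc1OC`) gives 42100 nM and compound 2 (`COc1cc(-c2ccc(-c3ccc(-c4nc5ccccc5[nH]4)cc3)cc2)cc(OC)c1OC`) gives 8010 nM as its reading. Within the data shown here, compound 2 thus holds the lower of only two numbers so far. Compound 3 (`COc1cc(-c2ccc(-c3ccc(-c4nc5c(O)cccc5[nH]4)cc3)cc2)cc(OC)c1OC`) differs from it by hydroxy in place of hydrogen on an aromatic carbon, which turns 1H-benzimidazol-2-yl into 4-hydroxy-1H-benzimidazol-2-yl. Among the measured compounds shown here, no measured step covers a hydroxy or this place. For the measured compounds named here, the only available step is methoxy in place of hydrogen on an aromatic carbon (a 5.3-fold lower number from compound 1 to compound 2 (0.72 log units; beyond the scatter)), which is modest and beyond the scatter. It involves a different group elsewhere in the molecule, so it bears only loosely on the new change. It does show that one added group can move the number in this assay by a modest amount. A step of similar or smaller size is therefore expected, more likely towards a lower number, though the data do not settle the direction. The expected move is a 1.6-fold lower number from compound 2 to compound 3 (0.20 log units; within the scatter) on this estimate. For compound 3 the estimated value is 5000 nM with an expected range of 1500 nM to 16000 nM as the likely span.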

Compound 3, concentration for 50% growth inhibition: 190 nM
The estimate for compound 3 lay 26-fold (1.42 log units) above the measured number; measured number below the stated range.
By their numbers in this assay, from the lowest: compound 3; then compound 2; then compound 1.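

In this assay, among these compounds, the change to 4-hydroxy-1H-benzimidazol-2-yl gives a 42-fold lower number from compound 2 to compound 3 (1.62 log units; beyond the scatter), a large step that the earlier compounds gave no sign of. It exceeds the modest 5.3-fold lower number from compound 1 to compound 2 (0.72 log units; beyond the scatter), so among the two changes shown, a hydroxy with 1 heavy atom on the six-membered aromatic ring of carbon only moves the number much further than the added methoxy at its different place. No evidence is available on what lies behind the size of this step.

The compounds shown leave open whether the hydroxy itself matters or whether an amine, a methoxy or a fluorine at this same place would give a step of similar size. They also leave open whether the same hydroxy would lower the number to a similar extent on the core of compound 1, and whether a hydroxy elsewhere on this six-membered aromatic ring would do the same.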